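Butoxy for dimethylamino on the five-membered aromatic ring

The source may hold more compounds than are shown below. What is called first, only, known or untested is meant among the compounds shown, and "the series" means these compounds.

Measured so far in a functional assay on MV4-11 cells (Homo sapiens) for inhibition, read by resazurin assay, with a stated time of 72 h; a higher number here means a weaker inhibitor of growth, a lower number a stronger inhibitor of growth:
compound 1 `COc1ccc(Nc2nccc(-c3sc(SC)nc3C)n2)c(OC)c1`: 530 nM
compound 2 `COCCOc1nc(C)c(-c2ccnc(Nc3ccc(OC)cc3OC)n2)s1`: 1980 nM
compound 3 `COc1ccc(Nc2nccc(-c3sc(N(C)C)nc3C)n2)c(OC)c1`: 170 nM

Compound 3 holds the lowest number of the three; the steps to it are a 3.1-fold lower number from compound 1 to compound 3 (0.49 log units; beyond the scatter) and a 12-fold lower number from compound 2 to compound 3 (1.07 log units; beyond the scatter), both beyond the scatter. Compound 4 `CCCCOc1nc(C)c(-c2ccnc(Nc3ccc(OC)cc3OC)n2)s1` keeps the core of compound 3 and differs in one group: butoxy in place of dimethylamino on an aromatic carbon. The step that bears most directly on this change is a 12-fold lower number from compound 2 to compound 3 (1.07 log units; beyond the scatter), read in reverse, since it exchanged dimethylamino for another alkoxy group on the same carbon; a 3.7-fold higher number from compound 1 to compound 2 (0.57 log units; beyond the scatter) shows that alkoxy group also behind methylsulfanyl in this assay. Butoxy is not 2-methoxyethoxy, so the size transfers only roughly, but a large rise in this assay is expected. Compound 4 is estimated at 1500 nM, within 500 nM to 4500 nM. That estimate means an expected step of an 8.8-fold higher number from compound 3 to compound 4 (0.95 log units; beyond the scatter).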

Compound 4, concentration for 50% growth inhibition: 7860 nM
Beside the measured number, compound 4's estimate is 5.2-fold (0.72 log units) below it; measured number above the stated range.
By their numbers in this assay, from the lowest: compound 3; then compound 1; then compound 2; then compound 4.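

Butoxy on this carbon gives a 46-fold higher number from compound 3 to compound 4 (1.66 log units; beyond the scatter) in this assay and so goes beyond the earlier exchange of dimethylamino for 2-methoxyethoxy. Butoxy also falls behind methylsulfanyl with a 15-fold higher number from compound 1 to compound 4 (1.17 log units; beyond the scatter) and behind 2-methoxyethoxy with a 4.0-fold higher number from compound 2 to compound 4 (0.60 log units; beyond the scatter) so both alkoxy groups rank behind both dimethylamino and methylsulfanyl, with no compound shown going against that order. No measurement available here accounts for this order. The compounds shown leave open where methoxy or a ring amine such as pyrrolidine would rank on this carbon.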